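The compounds below may be only part of what the source reports. "The series", "measured", "known", "first", "only" and "open" are said of these compounds alone.

Compound 1 `Cc1ccc(N2CCN(c3ccc(C(=O)/C=C/c4ccccc4)cc3)CC2)cc1` gives 2.85% in a functional assay on the whole organism (strain Kunming) for inhibition, with Mus musculus as the target, with a stated time of 1 h, at a dose of 40 mg/kg by the oral route (on this read-out higher numbers stand for more inhibition at the one dose given (going by the name of the read-out) and lower numbers for less inhibition), the lowest of the three numbers; compound 3 `O=C(/C=C/c1ccc(Cl)cc1)c1ccc(N2CCN(c3cccc(Cl)c3)CC2)cc1` with 5.85% sits within the scatter of it, while compound 2 `Cc1ccc(N2CCN(c3ccc(C(=O)/C=C/c4ccc(Cl)cc4)cc3)CC2)c(C)c1` with 25.7% stands well above. Among the measured compounds shown here, the one measured step, a number 19.9 percentage points lower from compound 2 to compound 3 (beyond the scatter), exchanges one aryl group for another on an amine nitrogen in a ring and shows that this place matters. Compound 4 `O=C(/C=C/c1ccccc1)c1ccc(N2CCN(S(=O)(=O)c3ccccc3)CC2)cc1` differs from compound 1 by phenylsulfonyl in place of 4-methylphenyl on an amine nitrogen in a ring. For the measured compounds named here, no measured step touches a phenylsulfonyl, so the direction is uncertain; compound 1 is already near the floor, leaving little room downward. For compound 4 a small upward step is expected, estimated at 8% with a range of 0% to 25%. For compound 4 the expected step is a number 5.2 percentage points higher from compound 1 to compound 4 (within the scatter).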

Compound 4, a percentage reported as inhibition, in the whole organism at one dose (the size of the read-out at that dose, not a potency): 30%
The estimate for compound 4 lay 22 percentage points below the measured number; measured number above the stated range.
By their numbers in this assay, from the lowest: compounds 1 and 3 (each within the scatter of the next); then compounds 2 and 4 (each within the scatter of the next).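

Phenylsulfonyl on the amine nitrogen in the ring gives a number 27.2 percentage points higher from compound 1 to compound 4 (beyond the scatter) in this assay, so this position also responds to a replacement that is not a simple aryl group. Among the compounds shown here, the earlier step showed only one aryl group exchanged for another, whereas here the sulfonyl brings in two hydrogen-bond acceptors and the number rises beyond the scatter. Nothing available explains this rise.

Open, as far as these compounds go, is whether a smaller methylsulfonyl or a benzoyl on the same nitrogen would give a similar number. Also open, from the compounds shown here alone, is whether phenylsulfonyl would give a step of this size on the core of compound 2.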